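Acyl chain shortening on the shared core

The source may hold more compounds than are shown below. What is called first, only, known or untested is meant among the compounds shown, and "the series" means these compounds.

Compound 2 `CCCCCCCCCCCCCCCCCC(=O)N[C@@H](CO)C[C@@H](O)c1ccccc1` carries the longer of the two measured acyl chains. In a functional assay on CHO cells (Cricetulus griseus) for inhibition (on this read-out lower numbers stand for stronger inhibition and higher numbers for weaker inhibition), compound 2 gives > 1000 nM, which is a limit of the assay rather than a number. Compound 1 `CCCCCCCCCCCCCCCCC(=O)N[C@@H](CO)C[C@@H](O)c1ccccc1` differs by a single chain carbon; in this assay compound 1 gives > 1000 nM, again a limit. The step that the two limits leave unreadable from compound 1 to compound 2 therefore cannot be sized. Both measured values sit at the same point, (the limit of > 1000 nM in this assay, at which 2 of the 2 values shown sit), so on the numbers shown compound 2 stands only at that limit and not at a defined place.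

Compound 3 `CCCCCCCCCC(=O)N[C@@H](CO)C[C@@H](O)c1ccccc1` is the unmeasured member. It differs from compound 2 by hydrogen in place of octyl on a saturated chain carbon, nine bonds along the chain from a carbonyl carbon. Among the compounds with values here, the only measured step, a step that the two limits leave unreadable from compound 1 to compound 2, concerns a methyl in place of hydrogen far along the chain from the carbonyl carbon and gives no readable size, so nothing measured bears directly on removing an octyl. The data in hand offer no handle on direction or size for this change. Compound 3 is therefore expected to give 3000 nM in this assay, within 500 nM to 30000 nM, most likely reported again as a limit. The expected step that the limit leaves unreadable from compound 2 to compound 3 is accordingly taken as none beyond the scatter.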

Compound 3, half-maximal inhibitory concentration: 300 nM
Beside the measured number, compound 3's estimate is 10-fold (1.00 log units) above it; the whole stated range lies above it.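

Within the data shown here, compound 3 gives the only defined number of the three in this assay, so a change at this place on the chain, nine bonds along from a carbonyl carbon, now has a readable direction: the number falls with hydrogen in place of octyl, an at least 3.3-fold lower number from compound 2 to compound 3 (0.52 log units; beyond the scatter), and with hydrogen in place of heptyl, an at least 3.3-fold lower number from compound 1 to compound 3 (0.52 log units; beyond the scatter). Compound 1 and compound 2 each stand at a limit, so both steps give only a minimum size, and the true size of the change may be larger. The step between compound 1 and compound 2 cannot be read, and the two longer chains share one point on the scale: the limit of > 1000 nM in this assay, at which 2 of the 3 values shown sit.

From the compounds shown here alone, with a single defined value, the shape of the relation between chain length and read-out stays open, including whether the change is gradual or sets in sharply somewhere between the chain of compound 3 and the longer ones. Also open, going by these compounds, is whether a still shorter chain, or a chain end carrying an amine or a carboxylic acid, would lower the number further or raise it again.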